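Methoxy to bromo on the sulfonyl aryl

The compounds below may be only part of what the source reports. "The series", "measured", "known", "first", "only" and "open" are said of these compounds alone.

Among the compounds with values here, in a functional assay on PC-3 cells (Homo sapiens) for cytotoxicity, read by MTT assay, with a stated time of 72 h (on this read-out higher numbers stand for weaker inhibition and lower numbers for stronger inhibition), compound 2 `COc1ccc(S(=O)(=O)c2nc3ccccc3nc2Nc2ccc(F)cc2)cc1` gives 2200 nM, the lowest of the two numbers so far. Compound 1 `COc1ccc(S(=O)(=O)c2nc3ccccc3nc2Nc2cc(OC)cc(OC)c2)cc1` gives 6220 nM in this assay. Within the data shown here, the one measured step is a 2.8-fold lower number from compound 1 to compound 2 (0.45 log units; beyond the scatter). Compound 3 `O=S(=O)(c1ccc(Br)cc1)c1nc2ccccc2nc1Nc1ccc(F)cc1` differs from compound 2 by bromo in place of methoxy on an aromatic carbon, cut one bond further out 4-methoxyphenyl to 4-bromophenyl, on the aromatic carbon para to a large group. The measured step concerns the other aryl, so nothing shown bears on this change; the expected step is no change at the digits printed from compound 2 to compound 3 (within the scatter), none beyond the scatter. Compound 3 is estimated at 2200 nM, range 800 nM to 6000 nM.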

Compound 3, half-maximal inhibitory concentration: 9160 nM
For compound 3 the middle estimate is 4.2-fold (0.62 log units) below the measured one; measured number above the stated range.
By their numbers in this assay, from the lowest: compound 2; then compounds 1 and 3 (each within the scatter of the next).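

The sulfonyl aryl is not a silent position in this assay: with the 4-fluorophenyl on the nitrogen held fixed, bromo in place of methoxy on the aromatic carbon para to a large group gives a 4.2-fold higher number from compound 2 to compound 3 (0.62 log units; beyond the scatter). Within the data shown here, the earlier step concerned only the aryl on the nitrogen, so this is the first sign that the substituent on the sulfonyl aryl also moves the number. Nothing available accounts for this step.

Open, from the compounds shown here alone, is how an unsubstituted phenyl, a chloro group or an amine would read at this carbon. Also open, going by these compounds, is whether the step holds with 3,5-dimethoxyphenyl on the nitrogen.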